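The compounds below may be only part of what the source reports. "The series", "measured", "known", "first", "only" and "open" are said of these compounds alone.

Measured so far in a physicochemical assay for lipophilicity; on this read-out higher numbers stand for higher lipophilicity and lower numbers for lower lipophilicity:
Compound 1 `C[C@H]1CC[C@@H]2[C@@H](OC(=O)[C@]23CC(c2c(Cl)cccc2Cl)=NO3)[C@]2(C)C(=O)C=C[C@@]12O`: 2.67
Compound 2 `C[C@H]1CC[C@@H]2[C@@H](OC(=O)[C@]23CC(c2cccc([N+](=O)[O-])c2)=NO3)[C@]2(C)C(=O)C=C[C@@]12O`: 1.37
Compound 3 `C[C@H]1CC[C@@H]2[C@@H](OC(=O)[C@]23CC(c2ccccc2)N(c2ccccc2)O3)[C@]2(C)C(=O)C=C[C@@]12O`: 3.19

Of these three, compound 3 stands highest, at 3.19. Compound 4 `C[C@H]1CC[C@@H]2[C@@H](OC(=O)[C@]23CC(c2c(F)c(F)c(F)c(F)c2F)N(c2ccccc2)O3)[C@]2(C)C(=O)C=C[C@@]12O` differs from it by 2,3,4,5,6-pentafluorophenyl in place of phenyl on a saturated ring carbon, which is 2,3,4,5,6-pentafluorophenyl in place of phenyl on a saturated ring carbon. Among the measured compounds shown here, only one measured step bears on this, and only loosely: a number 1.30 log units lower from compound 1 to compound 2 (beyond the scatter). That large step exchanged one aryl group for another, but on a carbon with a double bond to nitrogen, and it removed chlorine rather than adding fluorine. For the measured compounds named here, no measured step adds fluorine. Its direction, with the 2,6-dichlorophenyl compound 1 at 2.67, suggests a moderate rise beyond the scatter. The expected step is a number 0.71 log units higher from compound 3 to compound 4 (beyond the scatter). For compound 4 the estimate is 3.9, with an expected range of 3.4 to 4.4.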

Compound 4, partition coefficient: 3.72
For compound 4 the middle estimate is 0.18 log units above the measured one; the range from low to high includes it.
By their numbers in this assay, from the lowest: compound 2; then compound 1; then compound 3; then compound 4.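

In this assay, among the compounds shown here, 2,3,4,5,6-pentafluorophenyl in place of phenyl on the saturated ring carbon gives a number 0.53 log units higher from compound 3 to compound 4 (beyond the scatter) as the only measured step at this position. For the compounds shown here, it is also the only measured step that adds fluorine, whereas the earlier aryl exchange lay on a carbon with a double bond to nitrogen. No measured evidence accounts for this rise. Still open, going by these compounds, is how an amine or a carboxylic acid on this aryl ring would compare, and whether a single fluorine would move the number in the same direction.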